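The source may hold more compounds than are shown below. What is called first, only, known or untested is meant among the compounds shown, and "the series" means these compounds.

Of the compounds shown here, three from this series have been tested in a functional assay on BGC-823 cells (Homo sapiens) for cytotoxicity, read by CCK-8 assay, with a stated time of 72 h; on this read-out higher numbers stand for weaker inhibition and lower numbers for stronger inhibition. Compound 1 `COc1ccccc1/C=c1\c(=O)[nH]/c(=C/c2cccc(Cl)c2Cl)c(=O)n1C` gives 300 nM. Compound 2 `C=CCn1c(=O)/c(=C\c2ccc(F)c(Br)c2)[nH]c(=O)/c1=C\c1ccccc1OC` gives "not active" (no number reported), so no single number stands for it. Going by the values given here, compound 3 `COc1ccccc1/C=c1/[nH]c(=O)/c(=C\c2cccc(Cl)c2Cl)[nH]c1=O` likewise gives "not active" (no number reported), which means compound 2 is one of two entries without a number, while compound 1 is the only compound here with a measured concentration.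

Compound 4 `C=CCn1c(=O)/c(=C\c2ccccc2Cl)[nH]c(=O)/c1=C\c1ccccc1OC` has not yet been measured. It differs from compound 2 in one place: 2-chlorophenyl in place of 3-bromo-4-fluorophenyl on a double-bonded chain carbon bound to an aromatic carbon. Among the compounds with values here, since compound 2 carries no number, no step between measured compounds can be drawn for this change, and the direction of any shift in this assay cannot be read from the data. Within the data shown here, the only guide is that compound 1, with a differently substituted ring at the same kind of position, does show a measurable value, so a return to a numbered result for compound 4 seems possible but uncertain. Compound 4 is expected to give about 2000 nM, within a range from 300 nM to 20000 nM.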

Compound 4, half-maximal inhibitory concentration: 4600 nM
The estimate for compound 4 lay 2.3-fold (0.36 log units) below the measured number; measured number inside the range.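

Compound 4 gives 4600 nM while compound 2 has no number, and no step can be read between the two. How far 2-chlorophenyl in place of 3-bromo-4-fluorophenyl shifts activity stays open, and no supporting data here explain the value of compound 4.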